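The source may hold more compounds than are shown below. What is called first, only, known or untested is meant among the compounds shown, and "the series" means these compounds.

Measured compounds:

Compound 1, `COc1cccc(C2CCc3nc[nH]c3C2)c1`: 1050 nM
Compound 2, `Clc1cccc(C2CCc3nc[nH]c3C2)c1`: 514 nM
Compound 3, `COc1ccccc1C1Cc2nccn2C1`: 22 nM

The three measured compounds were tested in a functional assay on CHO cells for agonist activity at Alpha-1A adrenergic receptor (Homo sapiens), read by FLIPR and calcium flux; on this read-out lower numbers stand for an effect already at smaller amounts and higher numbers for an effect only at larger amounts of compound. Compound 1 gives 1050 nM, and compound 2, which carries chloro in place of methoxy on an aromatic carbon, gives 514 nM. That step, a 2.0-fold lower number from compound 1 to compound 2 (0.31 log units; beyond the scatter), is modest but beyond the scatter. Compound 3 is built on a different core; the difference between the two cores is not broken down here. In this assay compound 3 gives 22 nM, the lowest of the three numbers, beyond the scatter from both others.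

Compound 4, `Clc1ccccc1C1Cc2nccn2C1`, has not yet been measured. It differs from compound 3 by chloro in place of methoxy on an aromatic carbon. Within the data shown here, this is the same kind of change as the one from compound 1 to compound 2, though not the same: in compound 2 the chloro sits meta to a group of 9 heavy atoms, whereas in compound 4 it sits ortho to a group of 8 heavy atoms, and the cores differ. Among the measured compounds shown here, only one earlier instance of this change is known.

On that basis the step from compound 3 to compound 4 in this assay is expected to be about a 1.8-fold lower number from compound 3 to compound 4 (0.26 log units; within the scatter), resting on the size of the step from compound 1 to compound 2, a 2.0-fold lower number from compound 1 to compound 2 (0.31 log units; beyond the scatter), with wide uncertainty because the place of the change and the core are not the same. Compound 4 is therefore estimated at 12 nM, with a range from 4 nM to 40 nM.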

Compound 4, half-maximal effective concentration in the Alpha-1A adrenergic receptor assay: 19 nM
For compound 4 the middle estimate is 1.6-fold (0.20 log units) below the measured one, and the stated range covers the measured number.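

In the Alpha-1A adrenergic receptor assay, chloro in place of methoxy gives a 1.2-fold lower number from compound 3 to compound 4 (0.06 log units; within the scatter), yet the same change does not leave a physicochemical assay for lipophilicity, at pH 7.4 (on this read-out higher numbers stand for higher lipophilicity and lower numbers for lower lipophilicity), unmoved: the measured distribution coefficient of compound 3, 1.9, and of compound 4, 2.6, a number 0.70 log units higher (beyond the scatter) In the physicochemical assay compound 3 gives 1.9 and compound 4 gives 2.6 after this change. Set beside the earlier step, the new one does not differ from it beyond the scatter, so as far as these two pairs can tell, the change carries from one core to the other with a step of similar size: the same change on two cores in the Alpha-1A adrenergic receptor assay, a 2.0-fold lower number (0.31 log units; beyond the scatter) from compound 1 to compound 2 and a 1.2-fold lower number (0.06 log units; within the scatter) from compound 3 to compound 4, 1.8-fold (0.25 log units) apart, within the scatter of two such steps This does not establish a rule for other cores, since it rests on only two pairs, and these differ both in the core and in where the change sits on the aromatic ring, so the two influences cannot be told apart.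

The compounds shown leave open how groups other than methoxy and chloro, such as fluoro, a nitrile or an amine, would behave at this place on the core of compound 3 in the Alpha-1A adrenergic receptor assay. They also leave open whether the rise seen in the physicochemical assay on the core of compound 3 would recur on the core of compound 1, and whether a carboxylic acid on the aromatic ring would shift both read-outs together.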